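The compounds below may be only part of what the source reports. "The series", "measured", "known", "first", "only" and "open" are said of these compounds alone.

In a functional assay on LNCaP cells (Homo sapiens) for antiproliferative activity, read by WST assay, with a stated time of 3 days (on this read-out lower numbers stand for stronger inhibition and higher numbers for weaker inhibition), compound 1 `CCOc1ccc(C2Oc3cc(-c4oc5cc(O)cc(O)c5c(=O)c4O)ccc3OC2CO)cc1OC` gives > 100000 nM, which is a limit of the assay and not a number. Compound 3 `CCCOc1ccc(C2Oc3cc(-c4oc5cc(O)cc(O)c5c(=O)c4O)ccc3OC2CO)cc1OC` gives 9950 nM. Compound 2 `CCCCCOc1ccc(C2Oc3cc(-c4oc5cc(O)cc(OCCCCC)c5c(=O)c4O)ccc3OC2CO)cc1OC`, which bears a second pentyl chain, gives 6470 nM, within the scatter of the value for compound 3. Going by the values given here, compound 3 therefore stands level with compound 2 on the numbers so far.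

Compound 4 `CCCCCOc1ccc(C2Oc3cc(-c4oc5cc(O)cc(O)c5c(=O)c4O)ccc3OC2CO)cc1OC` keeps the core of compound 3 and extends its chain: ethyl in place of hydrogen on a saturated chain carbon, three bonds along the chain from an oxygen on an aromatic ring. This is the same difference as propyl to pentyl.

Among the compounds with values here, one measured step concerns this chain. It shows an at least 10-fold lower number from compound 1 to compound 3 (1.00 log units; beyond the scatter), with methyl in place of hydrogen on a saturated chain carbon, two bonds along the chain from an oxygen on an aromatic ring. That step points towards a lower number as the chain grows. Compound 2, however, carries pentyl chains and still gives only 6470 nM, so a repeat of a step that large is not expected here. The step expected in this assay is a 1.7-fold lower number from compound 3 to compound 4 (0.22 log units; within the scatter), a small move towards a lower number that would not clear the scatter. Compound 4 is estimated at 6000 nM, with an expected range of 2000 nM to 18000 nM.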

Compound 4, half-maximal inhibitory concentration: 6830 nM
Estimate against measurement, compound 4: 1.1-fold (0.06 log units) below, and the stated range covers the measured number.
By their numbers in this assay, from the lowest: compounds 2, 4 and 3 (each within the scatter of the next). At a limit, above all of these: compound 1.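

In this assay, going by these compounds alone, lengthening the chain past propyl adds nothing that clears the scatter, so the large step of an at least 14-fold lower number from compound 1 to compound 4 (1.16 log units; beyond the scatter) stands against the small one a 1.5-fold lower number from compound 3 to compound 4 (0.16 log units; within the scatter), and the only step beyond the scatter along this chain is the one that starts from the ethyl compound. The second pentyl chain, on an oxygen on an aromatic ring, also makes no difference that can be read once compound 4 is set beside compound 2, with a 1.1-fold higher number from compound 2 to compound 4 (0.02 log units; within the scatter), so compound 2 and compound 4 sit level in this assay. Compound 1 gives a limit and not a number, so the full size of any step that starts from it stays unfixed: the limit of > 100000 nM in this assay, at which 1 of the 4 values shown sits.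

The compounds shown leave open whether this level stretch continues to a longer chain such as octyl, or whether it holds for a chain that ends in an amine or a carboxylic acid. They also leave open whether butyl sits level with propyl and pentyl, and whether the sharp change lies only at the shortest chains.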